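Piperazine chain variation on the carbazolequinone core

The compounds below may be only part of what the source reports. "The series", "measured", "known", "first", "only" and "open" are said of these compounds alone.

Compound 1 `CN1CCN(CCCCCn2c3c(c4ccccc42)C(=O)c2c[n+]([O-])c4ccccc4c2C3=O)CC1` gives 830 nM in a functional assay on SH-SY5Y cells (Homo sapiens) for cytotoxicity, read by MTT assay, with a stated time of 72 h; on this read-out lower numbers stand for stronger inhibition and higher numbers for weaker inhibition. Compound 2 `CC1(C)OCC(Cn2cc(Cn3c4c(c5ccccc53)C(=O)c3c[n+]([O-])c5ccccc5c3C4=O)nn2)O1` gives 230 nM and compound 3 `O=C1c2c[n+]([O-])c3ccccc3c2C(=O)c2c1c1ccccc1n2Cc1cn([C@H]2O[C@H](CO)[C@@H](O)[C@H]2O)nn1` gives 1340 nM. Of these three numbers compound 1 holds the second highest; its gap to compound 3 lies within the scatter, while compound 2 sits beyond the scatter below it. Compound 4 `CCCCN1CCN(CCCCn2c3c(c4ccccc42)C(=O)c2c[n+]([O-])c4ccccc4c2C3=O)CC1` differs from compound 1 by 4-butylpiperazin-1-yl in place of (4-methylpiperazin-1-yl)methyl on a saturated chain carbon, four bonds along the chain from an aromatic nitrogen. Among the compounds with values here, the only measured step, a 5.8-fold higher number from compound 2 to compound 3 (0.77 log units; beyond the scatter), concerns the group on the aromatic nitrogen and not the chain end, so no measured step bears on this change. No step beyond the scatter is therefore expected; compound 4 is estimated at 830 nM (range 300 nM to 2300 nM), meaning an expected no change at the digits printed from compound 1 to compound 4 (within the scatter).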

Compound 4, half-maximal inhibitory concentration: 6100 nM
Compound 4: middle estimate off by 7.3-fold (0.87 log units), on the low side, and the stated range ends below it.
By their numbers in this assay, from the lowest: compound 2; then compounds 1 and 3 (each within the scatter of the next); then compound 4.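

Within the data shown here, the chain end is not a silent position: in this assay the change to 4-butylpiperazin-1-yl brings a 7.3-fold higher number from compound 1 to compound 4 (0.87 log units; beyond the scatter) and places compound 4 at the top of the series, which the earlier compounds, with no measured step at this site, could not show. Replacing (4-methylpiperazin-1-yl)methyl alters both the group on the piperazine and the chain carrying it, and this single step cannot separate the two. No measurement at hand accounts for the step.

Open, going by these compounds, is how 4-butylpiperazin-1-yl behaves on the chain of compound 1, and whether a morpholine at the chain end would read nearer compound 1 or compound 4.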